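This account rests on a few compounds, and the source may have more. Where it says the series, first, only, none or still open, it means among the compounds named here.

Measured in a functional assay on the whole organism (strain Swiss) with Mus musculus as the target; a higher number here means that more compound is needed for the effect, a lower number that less compound is needed:

Compound 1, `CC(C(=O)Nc1ccccc1)N1C(=O)CCC1=O`: 44.3 mg/kg
Compound 2, `CC(C(=O)Nc1cccc(Cl)c1)N1C(=O)CCC1=O`: 74.5 mg/kg
Compound 3, `CCC(C(=O)Nc1ccccc1)N1C(=O)CCC1=O`: 69.3 mg/kg

Compound 3 stands second highest of these three numbers. Compound 2 gives 74.5 mg/kg, and compound 3 gives 69.3 mg/kg, two values so close that nothing separates them. Going by the values given here, the only measured step into compound 3 is a 1.6-fold higher number from compound 1 to compound 3 (0.19 log units; within the scatter), a change that stays within the scatter of this assay.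

Compound 4, `CCC(C(=O)Nc1cccc(Cl)c1)N1C(=O)CCC1=O`, differs from compound 3 in one place: chloro in place of hydrogen on an aromatic carbon. The same change has been measured once, on the core without the extra methyl, as a 1.7-fold higher number from compound 1 to compound 2 (0.23 log units; within the scatter); that step, too, stays within the scatter. Nothing in the data points to the methyl altering what the chloro does, so a step of about the same small size, toward a higher number, is expected for compound 4: a 1.5-fold higher number from compound 3 to compound 4 (0.18 log units; within the scatter). On that basis, compound 4 is estimated at 105 mg/kg in this assay, with a range from 55 mg/kg to 200 mg/kg.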

Compound 4, dose for half-maximal effect: 43.4 mg/kg
Compound 4: middle estimate off by 2.4-fold (0.38 log units), on the high side, and the stated range ends above it.
By their numbers in this assay, from the lowest: compounds 4, 1, 3 and 2 (each within the scatter of the next).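

In this assay the chloro on the aromatic carbon does not repeat what it did on the core of compound 1: the step is now a 1.6-fold lower number from compound 3 to compound 4 (0.20 log units; within the scatter) and, though small on its own, it stands apart from the earlier step by more than the scatter: the same change on two cores in this assay, a 1.7-fold higher number (0.23 log units; within the scatter) from compound 1 to compound 2 and a 1.6-fold lower number (0.20 log units; within the scatter) from compound 3 to compound 4, 2.7-fold (0.43 log units) apart, beyond the scatter of two such steps. The methyl on the saturated chain carbon gives the mirror image, with a 1.7-fold lower number from compound 2 to compound 4 (0.23 log units; within the scatter) set against its earlier step: the same change on two cores in this assay, a 1.6-fold higher number (0.19 log units; within the scatter) from compound 1 to compound 3 and a 1.7-fold lower number (0.23 log units; within the scatter) from compound 2 to compound 4, 2.7-fold (0.43 log units) apart, beyond the scatter of two such steps. Across these four compounds, then, the two changes do not simply add up, and what one does depends on whether the other is present.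

From the compounds shown here alone, whether this dependence also holds for a fluoro or methoxy group on the aromatic ring stays open. The same question stands for a longer chain in place of the methyl.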